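A second trifluoromethyl on the aryl urea

The source may report more compounds than this note shows. Statements on the series, on what has been measured and on what is new or still open speak of the compounds shown alone.

Measured so far:
Compound 1, `Cc1cccc(NC(=O)N[C@H](C)c2ccccc2)c1`: 98%
Compound 2, `C[C@@H](NC(=O)Nc1cccc(C(F)(F)F)c1)c1ccccc1`: 72%

In an ADME assay on the whole organism with Oryza sativa as the target, tested at 1 uM (on this read-out lower numbers stand for a stronger effect and higher numbers for a weaker effect at the one concentration tested), compound 2 stands lowest of the two measured compounds; the nearest is compound 1, higher by a number 26 percentage points lower from compound 1 to compound 2 (beyond the scatter). Compound 3, `C[C@@H](NC(=O)Nc1cc(C(F)(F)F)cc(C(F)(F)F)c1)c1ccccc1`, is not yet measured. It differs from compound 2 by trifluoromethyl in place of hydrogen on an aromatic carbon. Going by the values given here, the one step measured, a number 26 percentage points lower from compound 1 to compound 2 (beyond the scatter), also introduced a trifluoromethyl on that ring and lowered the read-out beyond the scatter. A further lowering is therefore expected, likely smaller than the measured step, as a number 20 percentage points lower from compound 2 to compound 3 (beyond the scatter). Compound 3 is estimated at 52%, within 30% to 75%.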

Compound 3, a percentage reported as activity, at one concentration (the size of the read-out at that concentration, not a potency): 93%
The estimate for compound 3 lay 41 percentage points below the measured number; the whole stated range lies below it.
By their numbers in this assay, from the lowest: compound 2; then compounds 3 and 1 (each within the scatter of the next).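

In this assay, a second trifluoromethyl on the ring gives a number 21 percentage points higher from compound 2 to compound 3 (beyond the scatter), the opposite direction to a number 26 percentage points lower from compound 1 to compound 2 (beyond the scatter), the step that brought in the first. The lowering seen with the first trifluoromethyl therefore does not carry over to a second one at this position. No available evidence accounts for this reversal.

On these data alone, it remains open whether a smaller group here, such as fluorine or a nitrile, would leave the number near that of compound 2 or raise it as in compound 3. An amine at this position is also an open case.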